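The source may report more compounds than this note shows. Statements on the series, on what has been measured and on what is new or still open speak of the compounds shown alone.

Compound 1 `O=C(COc1ccc2cc(/C=C3/SC(=O)NC3=O)ccc2c1)Nc1ccccn1` carries a pyridin-2-yl group on the amide nitrogen of the shared core. In an assay on isolated protein for inhibition of histone deacetylase 8 (Homo sapiens), with a stated time of 1 h (on this read-out higher numbers stand for weaker inhibition and lower numbers for stronger inhibition), compound 1 gives only a limit, > 50000 nM, and not a number. Because of the limit of > 50000 nM in this assay, at which 2 of the 3 values shown sit, compound 1 cannot be ranked against compound 3 at all. Among the compounds with values here, compound 2 `O=C(COc1ccc2cc(/C=C3/SC(=O)NC3=O)ccc2c1)Nc1ccc(F)cc1` is the one measured compound with a real number: in this assay compound 2 gives 6600 nM. Compound 3 `O=C(COc1ccc2cc(/C=C3/SC(=O)NC3=O)ccc2c1)Nc1ccc(Cl)c(Cl)c1` again reaches only the limit in this assay, > 50000 nM.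

Compound 4 `O=C(COc1ccc2cc(/C=C3/SC(=O)NC3=O)ccc2c1)Nc1cccc(Cl)c1` differs from compound 1 by 3-chlorophenyl in place of pyridin-2-yl on an amide-type nitrogen. Within the data shown here, the steps that bear on it are an at least 7.5-fold lower number from compound 1 to compound 2 (0.87 log units; beyond the scatter) and an at least 7.5-fold higher number from compound 2 to compound 3 (0.87 log units; beyond the scatter), while a step that the two limits leave unreadable from compound 1 to compound 3. Among the measured compounds shown here, a single chlorine on the phenyl ring places compound 4 between the 4-fluorophenyl of compound 2 and the 3,4-dichlorophenyl of compound 3, so a drop from the limit that is smaller than the one seen for compound 2 is likely. For compound 4 the expected step is an at least 2.5-fold lower number from compound 1 to compound 4 (0.39 log units; beyond the scatter). Compound 4 is therefore estimated at 20000 nM, with a likely range from 5000 nM to 60000 nM.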

Compound 4, half-maximal inhibitory concentration: > 50000 nM
Compound 4: no number, only a limit; the forecaster's own chance of this, stated with the estimate: 40%; at least 2.5-fold (0.39 log units) between middle value and limit.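

In this assay compound 4 again gives only a limit, > 50000 nM, so hydrogen in place of chloro on an aromatic carbon of compound 3 does not by itself bring a readable number. A carbon-only aromatic ring on the amide-type nitrogen is therefore not enough to give a number, and the change from 4-fluorophenyl to 3-chlorophenyl brings an at least 7.5-fold higher number from compound 2 to compound 4 (0.87 log units; beyond the scatter). The steps from compound 1 and from compound 3 to compound 4 cannot be read: the limit of > 50000 nM in this assay, at which 3 of the 4 values shown sit.

The compounds shown cannot separate the kind of halogen from its place on the ring, and a 4-chlorophenyl or 3-fluorophenyl group would be needed to do so. They also leave open how an unsubstituted phenyl group, or an amine or carboxylic acid on the phenyl ring, would read in this assay.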